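The compounds below may be only part of what the source reports. "The series", "measured", "known", "first", "only" and "open" are said of these compounds alone.

Compound 1 `O=C(CCCCC1CCSS1)NCc1cn(CCCOc2ccc3cc(C(=O)O)c(=O)oc3c2)nn1` gives 43.4% in a functional assay on PC-12 cells (Rattus norvegicus) for cytotoxicity, read by MTT assay, with stated times of 3 h and 2 h, tested at 0.1 uM; a lower number here means a weaker effect, a higher number a stronger effect of the compound at the concentration tested.
Compound 2 `O=C(CCCCC1CCSS1)NCc1cn(CCCOc2ccc3cc(-c4ccccc4)c(=O)oc3c2)nn1` gives 33.9% in this assay.
Compound 3 `COc1ccc(-c2cc3ccc(OCCCn4cc(CNC(=O)CCCCC5CCSS5)nn4)cc3oc2=O)cc1` gives 42% in this assay.

Compound 3 stands second highest of the three numbers; its nearest neighbour is compound 1, and its furthest is compound 2. Its steps to both lie within the scatter: a number 1.4 percentage points lower from compound 1 to compound 3 (within the scatter) and a number 8.1 percentage points higher from compound 2 to compound 3 (within the scatter). The remaining step, a number 9.5 percentage points lower from compound 1 to compound 2 (within the scatter), is also within the scatter, so the three compounds are not separated in this assay.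

Compound 4 `O=C(CCCCC1CCSS1)NCc1cn(CCCOc2ccc3cc(-c4ccc(Cl)c(Cl)c4)c(=O)oc3c2)nn1` is not yet measured. It differs from compound 3 by 3,4-dichlorophenyl in place of 4-methoxyphenyl on an aromatic carbon. The closest measured step is a number 8.1 percentage points higher from compound 2 to compound 3 (within the scatter), which swaps a substituent on the same phenyl ring and changes nothing beyond the scatter; the other two steps, which replace the carboxy group by an aryl ring, are likewise within the scatter. Among the measured compounds shown here, no measured step covers the 3,4-dichlorophenyl group itself. From this compound 4 is expected to show no step beyond the scatter, a number 4 percentage points lower from compound 3 to compound 4 (within the scatter), and is estimated at 38%, between 26% and 50%.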

Compound 4, a percentage reported as activity, at one concentration (the size of the read-out at that concentration, not a potency): 38.1%
For compound 4 the middle estimate is 0.1 percentage points below the measured one; the measured number falls inside the stated range.
By their numbers in this assay, from the lowest: compounds 2, 4, 3 and 1 (each within the scatter of the next).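

Among the compounds shown here, with 3,4-dichlorophenyl at this position, on an aromatic carbon ortho to a group of 1 heavy atom, chlorine enters the aryl group for the first time, yet the result stays within the scatter of all three earlier compounds in this assay (a number 3.9 percentage points lower from compound 3 to compound 4 (within the scatter); a number 4.2 percentage points higher from compound 2 to compound 4 (within the scatter); a number 5.3 percentage points lower from compound 1 to compound 4 (within the scatter)). The change from 4-methoxyphenyl therefore adds no separation, and carboxy, phenyl, 4-methoxyphenyl and 3,4-dichlorophenyl remain indistinguishable here at the single concentration tested. No measurement given here bears on why the read-out stays unseparated.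

As far as these compounds go, whether an amine or a pyridine ring at this position would move the read-out beyond the scatter remains open. So does the effect of changes elsewhere in the shared core, such as a longer chain.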